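Trading the Fluorophenyl Arm for a Carboxy Group

This account rests on a few compounds, and the source may have more. Where it says the series, first, only, none or still open, it means among the compounds named here.

The account follows three measured pyrazole acids and one compound still awaiting its number. Compound 1 `Cc1n[nH]c(C(=O)O)c1Cc1cccc(-c2cccc(F)c2)c1` stands highest of the three in an assay on isolated protein for inhibition of 2-Hydroxyacid oxidase 2 (Homo sapiens), tested at 10 uM (on this read-out higher numbers stand for a stronger effect at the one concentration tested and lower numbers for a weaker effect), where compound 1 gives 50%. Compound 2 `Cc1n[nH]c(C(=O)O)c1Cc1cccc(-c2ccc(C(=O)O)cc2)c1` gives 15% in this assay, a value that sits beyond the scatter below that of compound 1, and compound 3 `Cc1c(Cc2cccc(-c3ccc(F)cc3)c2)c(C(=O)O)nn1C` gives 4%, the lowest of the three and likewise beyond the scatter from compound 1.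

The step of interest leads from compound 1 to compound 4 `Cc1n[nH]c(C(=O)O)c1Cc1cccc(C(=O)O)c1`. Compared with compound 1, compound 4 carries carboxy in place of 3-fluorophenyl on an aromatic carbon, the new group sitting on an aromatic carbon of a six-membered aromatic ring of carbon only, meta to a large group. Among the measured compounds shown here, no pair of measured compounds shows this change, so the size of the step is not known.

The surrounding numbers offer some guidance. For the measured compounds named here, compound 2, the only other compound bearing a carboxy on the benzyl side, gives 15%, well below compound 1. Compound 4 loses the whole fluorophenyl as well, so a loss beyond the scatter is expected, with the step from compound 1 to compound 4 in this assay estimated at a number 35 percentage points lower from compound 1 to compound 4 (beyond the scatter). For compound 4 in this assay the estimate is 15%, expected to lie between 0% and 38%.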

Compound 4, a percentage reported as inhibition, at one concentration (the size of the read-out at that concentration, not a potency): 0%
Beside the measured number, compound 4's estimate is 15 percentage points above it; low and high end bracket the measured number.
By their numbers in this assay, from the lowest: compounds 4 and 3 (each within the scatter of the next); then compound 2; then compound 1.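

Among the compounds shown here, putting carboxy in place of 3-fluorophenyl on this aromatic carbon, meta to a large group, gives a number 50 percentage points lower from compound 1 to compound 4 (beyond the scatter) in this assay, and this places the size of the change on record for the first time. Compound 2, which keeps a six-membered aromatic ring of carbon only at this place and carries its carboxy on that ring, gives 15% in this assay, while compound 4, which has no such ring, gives 0% in the same test, so among these two printed values some read-out remains only where the ring is kept. Nothing shown here explains the loss seen on this change.

The compounds shown leave open whether an unsubstituted phenyl, a pyridine or a 3-methoxyphenyl at this aromatic carbon would match compound 1, and so whether the fluorine itself counts for anything. They also leave open whether a small group without a ring, such as an amine, a hydroxyl or a methyl, would give any read-out here, or whether a carboxylic acid on a longer chain would differ from compound 4.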